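The compounds below may be only part of what the source reports. "The series", "measured", "known", "first", "only" and "open" are said of these compounds alone.

Compound 1 `C=C(Br)C(=O)Nc1ccc(/C=C2\SC(=O)N(CC)C2=O)cc1` carries a (1-bromoethenyl)carbonyl group on the aryl nitrogen and an ethyl group on the ring nitrogen of the shared core. In a functional assay on CCRF-CEM cells (Homo sapiens) for cytotoxicity, read by cell counting, with a stated time of 3 days (on this read-out higher numbers stand for weaker inhibition and lower numbers for stronger inhibition), compound 1 gives 870 nM, the lowest number among the three measured compounds. Compound 2 `CCN1C(=O)S/C(=C\c2ccc(N)cc2)C1=O` gives 91000 nM, and the step of a 100-fold higher number from compound 1 to compound 2 (2.02 log units; beyond the scatter) shows how much the (1-bromoethenyl)carbonyl group contributes. Compound 3 `Nc1cccc(/C=C2\SC(=O)N(Cc3cccc(Cl)c3)C2=O)c1` gives 195000 nM; it differs from compound 2 in more than one place, so its two values are only set side by side: compound 3 sits at a higher number than compound 2.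

Compound 4 `C=C(Br)C(=O)Nc1ccc(/C=C2\SC(=O)N(Cc3cccc(Cl)c3)C2=O)cc1` keeps the (1-bromoethenyl)carbonyl group of compound 1 and changes the ring-nitrogen substituent: 3-chlorophenyl in place of methyl on a saturated chain carbon bound to an amide-type nitrogen in a ring. Among the compounds with values here, no measured step covers this change alone, since compound 3 carries the 3-chlorobenzyl group together with a free amine on a different ring position. The step from compound 1 to compound 4 is therefore expected to stay within the scatter, a 1.0-fold higher number from compound 1 to compound 4 (0.01 log units; within the scatter). Compound 4 is expected to give about 900 nM, between 300 nM and 3000 nM.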

Compound 4, half-maximal inhibitory concentration: 3700 nM
For compound 4 the middle estimate is 4.1-fold (0.61 log units) below the measured one; the whole stated range lies below it.
By their numbers in this assay, from the lowest: compound 1; then compound 4; then compound 2; then compound 3.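

The ring-nitrogen position is not neutral: in this assay, going from ethyl to 3-chlorobenzyl with the (1-bromoethenyl)carbonyl group held in place brings a 4.3-fold higher number from compound 1 to compound 4 (0.63 log units; beyond the scatter) on this change alone. That step is modest, whereas removing the (1-bromoethenyl)carbonyl group brings the large step of a 100-fold higher number from compound 1 to compound 2 (2.02 log units; beyond the scatter) in the same assay, so in this pair of changes the aryl-nitrogen group remains the larger contributor. Nothing available gives a reason for the step at the ring nitrogen.

With the (1-bromoethenyl)carbonyl group in place, only ethyl and 3-chlorobenzyl are shown at this position, so the separate shares of the aromatic ring and the chlorine remain open. A plain benzyl group, a longer alkyl chain or a chain ending in an amine would help to separate them.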